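A few compounds are considered here, and "the series" means these few. Any claim that something is new, unique, unknown or untested is made for them only; others in the source may bear on it.

For the measured compounds named here, compound 1 (`FC(F)(F)c1ccc(CSc2nc(N3CCNCC3)cc(C(F)(F)F)n2)cc1`) gives 6210 nM in a functional assay on NCI-H1975 cells (Homo sapiens) for inhibition, read by MTT assay, with a stated time of 72 h (on this read-out lower numbers stand for stronger inhibition and higher numbers for weaker inhibition), the lowest of the two numbers measured so far. Compound 3 (`FC(F)(F)c1ccc(CSc2nc(N3CCN(c4ccccn4)CC3)cc(C(F)(F)F)n2)cc1`) gives 17400 nM. Compound 2 (`FC(F)(F)c1ccc(CSc2nc(N3CCN(c4ccccc4)CC3)cc(C(F)(F)F)n2)cc1`) is reported only as a limit, > 50000 nM.

The step now in question leads to compound 4 (`Cc1csc(Sc2cc(C(F)(F)F)nc(SCc3ccc(C(F)(F)F)cc3)n2)n1`), with (4-methyl-1,3-thiazol-2-yl)sulfanyl in place of piperazin-1-yl on an aromatic carbon. Going by the values given here, no measured step makes this replacement. The three measured steps all keep the piperazin-1-yl group and change only what sits on its amine nitrogen, so they bear on it only indirectly. Both steps away from compound 1 raise the number, phenyl giving an at least 8.0-fold higher number from compound 1 to compound 2 (0.90 log units; beyond the scatter) and pyridin-2-yl giving a 2.8-fold higher number from compound 1 to compound 3 (0.45 log units; beyond the scatter). Between those two aromatic groups, the measured difference is an at least 2.8-fold lower number from compound 2 to compound 3 (0.45 log units; beyond the scatter).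

In both measured cases, then, a larger group with an aromatic ring went with a weaker result than compound 1, and neither compound goes against this. On that limited basis, a modest to moderate rise is expected in this assay rather than a fall. The expected change is a 2.6-fold higher number from compound 1 to compound 4 (0.41 log units; beyond the scatter). Compound 4 is estimated at 16000 nM, with an expected range from 5000 nM to 50000 nM.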

Compound 4, half-maximal inhibitory concentration: 5840 nM
The estimate for compound 4 lay 2.7-fold (0.44 log units) above the measured number; the measured number falls inside the stated range.
By their numbers in this assay, from the lowest: compounds 4 and 1 (each within the scatter of the next); then compound 3. At a limit, above all of these: compound 2.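

For the compounds shown here, compound 4 shows that the whole piperazin-1-yl group can be exchanged at this position without a change beyond the scatter, whereas the earlier compounds varied only what sits on its amine nitrogen: a 1.1-fold lower number from compound 1 to compound 4 (0.03 log units; within the scatter) in this assay. The entering (4-methyl-1,3-thiazol-2-yl)sulfanyl has an aromatic ring and no hydrogen-bond donors, so the donor of the piperazin-1-yl group is not needed to keep this level of inhibition, and compound 4 goes against the earlier trend, seen in compounds 2 and 3, of a larger group with an aromatic ring going with a weaker result. Nothing measured here accounts for why this exchange leaves the number within the scatter.

The compounds shown leave open how much the sulfur link, the thiazole ring and its methyl group each contribute, as all three enter together in a single step. From the compounds shown here alone, it also remains open whether a morpholine, a simple open-chain amine or a carboxylic acid at this position would fit with compound 1 and compound 4 or with the weaker compounds.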